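Two Chlorines Replace a Nitrile on the Second Aryl Group

The source may hold more compounds than are shown below. What is called first, only, known or untested is meant among the compounds shown, and "the series" means these compounds.

Three compounds share a core in which a tert-butyl group sits on a nitrogen flanked by two aromatic amide units. Compound 1 `CC(C)(C)N(NC(=O)c1ccccc1)C(=O)c1ccccc1Br` carries a 2-bromophenyl and a plain phenyl; compound 2 `CC(C)(C)N(NC(=O)c1ccccc1)C(=O)c1ccc(Cl)cc1Cl` carries a 2,4-dichlorophenyl and a plain phenyl; compound 3 `CC(C)(C)N(NC(=O)c1cccc(C#N)c1)C(=O)c1ccccc1Cl` carries a 2-chlorophenyl and a 3-cyanophenyl. In an assay on cells for agonist activity at ecdysone receptor (Bombyx mori), read by a luciferase reporter, with a stated time of 24 h (on this read-out higher numbers stand for an effect only at larger amounts of compound and lower numbers for an effect already at smaller amounts), compound 1 gives 170 nM, compound 2 gives 117 nM, and compound 3 gives 955 nM. Compound 3 thus stands highest of the three, a gap beyond the scatter from both others, while a 1.5-fold lower number from compound 1 to compound 2 (0.16 log units; within the scatter) stays within the scatter.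

Compound 4 `CC(C)(C)N(NC(=O)c1cccc(Cl)c1Cl)C(=O)c1ccccc1Cl` arises from compound 3 by one change: 2,3-dichlorophenyl in place of 3-cyanophenyl on a carbonyl carbon. Among the compounds with values here, no measured step touches this position; the only step known alters the other carbonyl's aryl group and is small. Still, compound 3, the only one bearing a substituent on this carbonyl, also carries the highest number, whereas compounds 1 and 2 sit much lower. A move back toward their range is therefore expected for compound 4, roughly a 6.4-fold lower number from compound 3 to compound 4 (0.80 log units; beyond the scatter), giving an estimate of 150 nM with a range from 40 nM to 600 nM.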

Compound 4, half-maximal effective concentration: 9.33 nM
Compound 4: the middle estimate sits 16-fold (1.21 log units) above what was measured, outside the stated range (below it).
By their numbers in this assay, from the lowest: compound 4; then compounds 2 and 1 (each within the scatter of the next); then compound 3.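

Replacing the 3-cyanophenyl with 2,3-dichlorophenyl on this carbonyl carbon gives, in this assay, a 100-fold lower number from compound 3 to compound 4 (2.01 log units; beyond the scatter), so the aryl group at this place can by itself shift the number very far. Within the data shown here, the only earlier step, a 1.5-fold lower number from compound 1 to compound 2 (0.16 log units; within the scatter), changed the other carbonyl's aryl group and gave no hint of such sensitivity here. Nothing measured here explains the size of this step.

From the compounds shown here alone, the change removes a nitrile and brings in two chlorine atoms in a single move, so the share of each remains unknown. Going by these compounds, it also remains open whether a single chlorine, a methoxy group or an amine on this aryl group would give a number near that of compound 4 or near that of compound 3.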